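The compounds below may be only part of what the source reports. "The series", "measured", "known", "first", "only" and "open" are said of these compounds alone.

Measured in a functional assay on A549 cells (Homo sapiens) for inhibition, read by sulforhodamine B assay, with a stated time of 72 h; a higher number here means a weaker inhibitor, a lower number a stronger inhibitor:
- compound 1 `COc1cc2c(Nc3ccc(F)c(Cl)c3)ncnc2cc1OCCCn1ccnc1[N+](=O)[O-]`: 4310 nM
- compound 2 `COc1cc2c(Nc3ccc(OCc4cccc(F)c4)c(Cl)c3)ncnc2cc1OCCCCCCn1ccnc1[N+](=O)[O-]`: > 50000 nM, a limit
- compound 3 `COc1cc2c(Nc3cccc(Br)c3)ncnc2cc1OCCCn1ccnc1[N+](=O)[O-]`: 7830 nM

Going by the values given here, compound 3, at 7830 nM, has only one numeric neighbour, and the two lie within the scatter: a 1.8-fold higher number from compound 1 to compound 3 (0.26 log units; within the scatter). Compound 4 `COc1cc2c(Nc3cccc(Br)c3)ncnc2cc1OCCCCCCn1ccnc1[N+](=O)[O-]` keeps the 3-bromophenyl group and changes the chain, with 3-(2-nitro-1H-imidazol-1-yl)propyl in place of 2-nitro-1H-imidazol-1-yl on a saturated chain carbon, three bonds along the chain from an oxygen on an aromatic ring. Among the compounds with values here, the one numeric step concerns the other end of the molecule, so it says nothing about this change. Within the data shown here, compound 2, the only measured compound with the longer chain, gives a limit, > 50000 nM, so a weaker reading is expected for compound 4. The expected change is a 2.0-fold higher number from compound 3 to compound 4 (0.31 log units; beyond the scatter), towards a higher number. For compound 4 the estimated value is 16000 nM, with an expected range of 6000 nM to 50000 nM.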

Compound 4, half-maximal inhibitory concentration: 20200 nM
The estimate for compound 4 lay 1.3-fold (0.10 log units) below the measured number, within the range that was stated.
By their numbers in this assay, from the lowest: compounds 1 and 3 (each within the scatter of the next); then compound 4. At a limit, above all of these: compound 2.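

Lengthening the chain gives the first readable step at this position: in this assay there is a 2.6-fold higher number from compound 3 to compound 4 (0.41 log units; beyond the scatter), a modest loss with the 3-bromophenyl group held fixed. Compound 4 therefore keeps a numeric reading with the longer chain. Compound 2, which carries the same chain, gives only a limit: the limit of > 50000 nM in this assay, at which 1 of the 4 values shown sits.

The compounds shown leave open how the reading changes with a chain of another length. They also leave open whether the 2-nitro-1H-imidazol-1-yl group matters at all, which an amine or a carboxylic acid at the chain end would test.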